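Chloro for hydroxy on the benzamide ring of a hydrazone

The source may report more compounds than this note shows. Statements on the series, on what has been measured and on what is new or still open speak of the compounds shown alone.

Measured so far:
compound 1 `COc1ccc(C(=O)N(C)/N=C/c2ccc(OC)c(OC)c2)cc1` 61%
compound 2 `COc1ccc(/C=N/N(C)C(=O)c2ccc(O)cc2)cc1OC` 36%

Compound 2 stands lowest of the two numbers in a functional assay on the whole organism (strain A/J) for inhibition, with Mus musculus as the target, with stated times of 1 h and 18 h, at a dose of 100 umol/kg by the oral route; a higher number here means more inhibition at the dose given (going by the name of the read-out), a lower number less inhibition; its nearest neighbour is compound 1, whose number in this assay is higher. Compound 3 `COc1ccc(/C=N/N(C)C(=O)c2ccc(Cl)cc2)cc1OC` differs from compound 2 by chloro in place of hydroxy on an aromatic carbon. Among the measured compounds shown here, the only step measured, a number 25 percentage points lower from compound 1 to compound 2 (beyond the scatter), bears on it: there a hydroxy entering in place of a methyl on an oxygen lowered the number. Since the hydroxy now leaves again, compound 3 is expected to gain back a step of comparable size, a number 19 percentage points higher from compound 2 to compound 3 (beyond the scatter). The estimate for compound 3 is 55%, within 30% to 78%.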

Compound 3, a percentage reported as inhibition, in the whole organism at one dose (the size of the read-out at that dose, not a potency): 33%
Beside the measured number, compound 3's estimate is 22 percentage points above it; the range from low to high includes it.
By their numbers in this assay, from the lowest: compounds 3 and 2 (each within the scatter of the next); then compound 1.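

In this assay chloro and hydroxy are not told apart on this aromatic carbon (a number 3 percentage points lower from compound 2 to compound 3 (within the scatter)), although only hydroxy counts a hydrogen-bond donor. Methoxy at the same place stands apart from chloro as it did from hydroxy (a number 28 percentage points lower from compound 1 to compound 3 (beyond the scatter)), so the lower number is not tied to hydroxy alone. Nothing given here accounts for this result. From the compounds shown here alone, it remains open whether an amine or a carboxylic acid on this carbon would stay with compound 2 and compound 3 or come nearer to compound 1.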